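Amine swap on the sulfonyl sulfur of compound 2

The source may hold more compounds than are shown below. What is called first, only, known or untested is meant among the compounds shown, and "the series" means these compounds.

Within the data shown here, compound 2 `CN(C)S(=O)(=O)CCNc1nonc1/C(=N/O)Nc1ccc(F)c(Br)c1` gives 105 nM in an assay on isolated protein for inhibition of Indoleamine 2,3-dioxygenase 1 (Homo sapiens), read by fluorescence, with a stated time of 60 min (on this read-out lower numbers stand for stronger inhibition and higher numbers for weaker inhibition), the lowest of the two numbers measured so far; compound 1 `[O-][S+]1CC(Nc2nonc2/C(=N/O)Nc2ccc(F)c(Br)c2)C1` gives 212 nM, and the step of a 2.0-fold lower number from compound 1 to compound 2 (0.31 log units; beyond the scatter) is the only one in hand. Compound 3 `C#CCNS(=O)(=O)CCNc1nonc1/C(=N/O)Nc1ccc(F)c(Br)c1` carries propargylamino in place of dimethylamino on a sulfonyl sulfur. Among the measured compounds shown here, no measured step touches this amine alone: the step of a 2.0-fold lower number from compound 1 to compound 2 (0.31 log units; beyond the scatter) replaced the whole side chain, so it bears only loosely on the change. The expected step of no change at the digits printed from compound 2 to compound 3 (within the scatter) is therefore none beyond the scatter. Compound 3 is estimated at 105 nM, with a range from 50 nM to 250 nM.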

Compound 3, half-maximal inhibitory concentration: 218 nM
For compound 3 the middle estimate is 2.1-fold (0.32 log units) below the measured one; measured number inside the range.
By their numbers in this assay, from the lowest: compound 2; then compounds 1 and 3 (each within the scatter of the next).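

On a sulfonyl sulfur the amine is not a silent position: propargylamino in place of dimethylamino gives a 2.1-fold higher number from compound 2 to compound 3 (0.32 log units; beyond the scatter), so the side chain of compound 2 owes its number partly to this terminal group. With the amine changed, the open chain no longer separates from the four-membered ring, as a 1.0-fold higher number from compound 1 to compound 3 (0.01 log units; within the scatter) shows. Nothing measured accounts for the step.

Open, from the compounds shown here alone, is whether the step follows the triple bond or the hydrogen-bond donor that enters with propargylamino. A propylamino group on the sulfonyl sulfur would separate the two, and a morpholine would test a ring there.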